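From benzyl to 4-nitrophenyl: a toxicity estimate

The source may hold more compounds than are shown below. What is called first, only, known or untested is meant among the compounds shown, and "the series" means these compounds.

Measured so far in a toxicity assay on cells (Macrophage, Mus musculus, strain BALB/c) for cytotoxicity, read by MTT assay; a higher number here means a weaker inhibitor, a lower number a stronger inhibitor:
- Compound 1 `C=CCOc1cc(OC)c(C(=O)/C=C/Cc2ccccc2)c(OCC=C)c1`: 14800 nM
- Compound 2 `COc1cc(O)cc(O)c1C(=O)/C=C/Cc1ccccc1`: 27000 nM
- Compound 3 `COc1cc(/C=C/C(=O)c2c(O)cc(O)cc2OC)ccc1O`: "not determined" (no result reported)

Among the compounds with values here, only two compounds in this small set have a number. Compound 1 gives 14800 nM and compound 2 gives 27000 nM, and these two values lie within the usual scatter of repeated measurements. Compound 1 therefore cannot be separated from compound 2 in this assay, and compound 3 adds no number for comparison.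

The next compound to be tested is compound 4 `C=CCOc1cc(OC)c(C(=O)/C=C/c2ccc([N+](=O)[O-])cc2)c(OCC=C)c1`. It keeps the core of compound 1 but carries 4-nitrophenyl in place of benzyl on a double-bonded chain carbon bound to a double-bonded chain carbon.

Within the data shown here, no measured pair in this set shows what such a swap does, so any forecast is loose. The closeness of the two known values suggests only a general range for this family, and the direction is a tentative judgement. The expected change is a 1.6-fold lower number from compound 1 to compound 4 (0.22 log units; within the scatter), a modest move toward a lower number that may not clear the scatter. For compound 4 the estimated value is 9000 nM, with an expected range from 2500 nM to 30000 nM.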

Compound 4, half-maximal inhibitory concentration: 13200 nM
Beside the measured number, compound 4's estimate is 1.5-fold (0.17 log units) below it; measured number inside the range.
By their numbers in this assay, from the lowest: compounds 4, 1 and 2 (each within the scatter of the next, the first and the last beyond it).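

In this assay, putting 4-nitrophenyl in place of benzyl on a double-bonded chain carbon bound to a double-bonded chain carbon gives a 1.1-fold lower number from compound 1 to compound 4 (0.05 log units; within the scatter) and so leaves the two compounds impossible to tell apart. Within the data shown here, the earlier compounds offered no pair differing in one place, so this is the first direct reading of this position: a carbon-only benzyl can give way to a 4-nitrophenyl, which brings nitrogen, oxygen and hydrogen-bond acceptors, with no shift that can be separated from the scatter in this cell test. No supporting measurement is available to explain this outcome.

On these data alone, one swap at one position cannot show how far this tolerance extends, and it remains open whether a 4-aminophenyl, a 4-carboxyphenyl or a longer carbon chain at the same place would give a number clearly apart from that of compound 1 in this assay as well. As far as these compounds go, it also remains open whether the same exchange would read alike on the core of compound 2, which has hydroxyl groups where compound 1 has allyl ethers.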